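A few compounds are considered here, and "the series" means these few. Any claim that something is new, unique, unknown or untested is made for them only; others in the source may bear on it.

The measured compounds:
Compound 1 `O=C(CCCCC1CCSS1)NCc1cn(CCCOc2ccc3cc(C(=O)O)c(=O)oc3c2)nn1` gives 52.1% in a functional assay on PC-12 cells (Rattus norvegicus) for cytotoxicity, read by MTT assay, with stated times of 3 h and 2 h, tested at 1 uM; on this read-out lower numbers stand for a weaker effect and higher numbers for a stronger effect at the one concentration tested.
Compound 2 `O=C(CCCCC1CCSS1)NCc1cn(CCCOc2ccc3cc(-c4ccc(Br)cc4)c(=O)oc3c2)nn1` gives 42.8% in this assay.

Compound 2 shows the lowest of the two numbers in this assay; its nearest neighbour is compound 1, and the step of a number 9.3 percentage points lower from compound 1 to compound 2 (within the scatter) lies within the scatter, so the two compounds cannot be told apart on this read-out. Compound 3 `O=C(CCCCC1CCSS1)NCc1cn(CCCOc2ccc3cc(-c4ccc(Cl)cc4)c(=O)oc3c2)nn1` differs from compound 2 by chloro in place of bromo on an aromatic carbon. Among the compounds with values here, only one step has been measured so far, and it concerns a different change, 4-bromophenyl in place of carboxy on an aromatic carbon; it was small, a number 9.3 percentage points lower from compound 1 to compound 2 (within the scatter). Within the data shown here, no step exchanging chloro for bromo has been measured, so nothing bears directly on the step to compound 3. For compound 3 one therefore expects no step beyond the scatter in this assay, that is a number 0.2 percentage points higher from compound 2 to compound 3 (within the scatter). Compound 3 is estimated at 43%, with a range from 30% to 56%.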

Compound 3, a percentage reported as activity, at one concentration (the size of the read-out at that concentration, not a potency): 49.3%
The estimate for compound 3 lay 6.3 percentage points below the measured number, and the stated range covers the measured number.
By their numbers in this assay, from the lowest: compounds 2, 3 and 1 (each within the scatter of the next).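

Chloro in place of bromo, on an aromatic carbon of a six-membered aromatic ring of carbon only, para to a large group, gives in this assay a number 6.5 percentage points higher from compound 2 to compound 3 (within the scatter), so this exchange of halogens does not separate the two compounds on this read-out. The replacement of carboxy by 4-chlorophenyl on an aromatic carbon gives a number 2.8 percentage points lower from compound 1 to compound 3 (within the scatter), so this aryl group, like the 4-bromophenyl group before it, cannot be told apart from carboxy, and all three compounds lie within the scatter of one another. Nothing available accounts for these numbers.

Still open, on these data alone, is whether an amine or a nitrile in place of the halogen would give a step beyond the scatter. Also open, as far as these compounds go, is whether a longer chain in place of the 4-chlorophenyl group would do so.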